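Furan-2-yl carbonyl in place of 4-chlorophenyl carbonyl

The source may report more compounds than this note shows. Statements on the series, on what has been measured and on what is new or still open speak of the compounds shown alone.

Compound 1 `Cc1cccc(Cn2c(CN3CCN(C(=O)c4ccc(Cl)cc4)CC3)nc3ccccc32)c1` gives 23.2% in an assay on isolated protein for inhibition of aldehyde dehydrogenase 1A1 (Homo sapiens), read by spectrophotometry, tested at 10 uM (a lower number here means less inhibition, a higher number more inhibition at the concentration tested (going by the name of the read-out)), the lowest of the three numbers measured; compound 3 `O=C(C1CC1)N1CCN(Cc2nc3ccccc3n2Cc2ccc(F)cc2)CC1` gives 32.7%, within the scatter of compound 1, while compound 2 `O=C(C1CC1)N1CCN(Cc2nc3ccccc3n2Cc2ccc(Cl)cc2)CC1` gives 56.6%, beyond it. Going by the values given here, the one step between single-change neighbours, a number 23.9 percentage points lower from compound 2 to compound 3 (beyond the scatter), concerns the ring on the benzyl arm, not the carbonyl substituent, so no measured step bears directly on the change to compound 4 `Cc1cccc(Cn2c(CN3CCN(C(=O)c4ccco4)CC3)nc3ccccc32)c1`: furan-2-yl in place of 4-chlorophenyl on a carbonyl carbon. Compound 2 carries a different carbonyl substituent but also a different benzyl ring, so its value shows nothing separable. Among the compounds with values here, with no bearing step, a change in this assay within the scatter is expected, a number 3.2 percentage points lower from compound 1 to compound 4 (within the scatter). Compound 4 is estimated at 20%, range 5% to 40%.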

Compound 4, a percentage reported as inhibition, at one concentration (the size of the read-out at that concentration, not a potency): 73.2%
Beside the measured number, compound 4's estimate is 53.2 percentage points below it, and the stated range ends below it.
By their numbers in this assay, from the lowest: compounds 1 and 3 (each within the scatter of the next); then compound 2; then compound 4.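

Furan-2-yl in place of 4-chlorophenyl on a carbonyl carbon gives a number 50 percentage points higher from compound 1 to compound 4 (beyond the scatter) in this assay. Going by these compounds alone, the carbonyl substituent, which no earlier step touched, can therefore shift this read-out strongly while the rest of compound 1 stays unchanged. No available evidence accounts for this step.

Open, as far as these compounds go, is whether the step comes from the furan-2-yl ring or from the loss of the 4-chlorophenyl group; plain phenyl or thiophen-2-yl on the same carbonyl carbon would bear on this. Also open, from the compounds shown here alone, is whether the step holds with the benzyl ring of compound 2.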